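The compounds below may be only part of what the source reports. "The series", "measured", "known", "first", "only" and "open" are said of these compounds alone.

Measured compounds:
- compound 1 `NCc1ccc(C(=O)Nc2ccncc2F)cc1-c1cccc(NC(=O)c2cccc(C(=O)O)c2)c1`: < 1 nM
- compound 2 `CCCOC(=O)c1ccc(NC(=O)c2cccc(-c3cc(C(=O)Nc4ccncc4F)ccc3CN)c2)cc1`: < 1 nM

In an assay on cells for inhibition of Rho-associated protein kinase 2 (Homo sapiens), read by radiometric assay and 33P incorporation, in the presence of a further agent that is not named here (a higher number here means a weaker inhibitor, a lower number a stronger inhibitor), compound 1 reaches only the limit of the assay, < 1 nM, so no number is known for it. Compound 2 likewise sits at a limit, < 1 nM. Both values shown therefore rest at the limit of < 1 nM in this assay, at which 2 of the 2 values shown sit, and compound 1 cannot be placed relative to compound 2 on the numbers shown.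

Compound 3 `COC(=O)c1ccc(C(=O)Nc2cccc(-c3cc(C(=O)Nc4ccncc4F)ccc3CN)c2)cc1` differs from compound 1 by one change: 4-(methoxycarbonyl)phenyl in place of 3-carboxyphenyl on a carbonyl carbon. Within the data shown here, no measured pair describes a step of this kind, and with both known values at the limit there is no numerical anchor for the direction. The step that the limit leaves unreadable from compound 1 to compound 3 is expected to be none beyond the scatter. Compound 3 is accordingly expected to give about 0.6 nM in this assay, with a range from 0.2 nM to 2 nM, and most likely again only a limit.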

Compound 3, half-maximal inhibitory concentration: < 1 nM
Compound 3 was reported as a limit; the forecaster's own chance of this, stated with the estimate: 80%; the middle value does not contradict the limit.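

No step can be read from compound 1 to compound 3, because each of them is reported only as a limit: the limit of < 1 nM in this assay, at which 3 of the 3 values shown sit.

The compounds shown leave open whether 4-(methoxycarbonyl)phenyl in place of 3-carboxyphenyl on a carbonyl carbon changes the potency in this assay at all, and by how much.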